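Isobutyl on the amide of compound 1

The compounds below may be only part of what the source reports. "The series", "measured", "known", "first", "only" and "open" are said of these compounds alone.

Among the compounds with values here, in a functional assay on MCF7 cells (Homo sapiens) for antiproliferative activity, read by CCK-8 assay, with a stated time of 72 h (on this read-out lower numbers stand for stronger inhibition of growth and higher numbers for weaker inhibition of growth), compound 1 `CC[C@@H]1C(=O)N(C)c2cnc(-n3ccc4cc(C(N)=O)ccc43)nc2N1C1CCCC1` gives 1830 nM and stands highest of the two numbers so far, with compound 2 `CC[C@@H]1C(=O)N(C)c2cnc(Nc3ccc(S(=O)(=O)NC4CCCC4)cc3)nc2N1C1CCCC1` at 688 nM lower by more than the scatter. Compound 3 `CC[C@@H]1C(=O)N(C)c2cnc(-n3ccc4cc(C(=O)NCC(C)C)ccc43)nc2N1C1CCCC1` carries the change isobutyl in place of hydrogen on an amide-type nitrogen in the form of isobutyl in place of hydrogen on an amide-type nitrogen. Within the data shown here, no measured pair shows this change, so in this assay no step beyond the scatter is expected, and the estimated move a 1.2-fold lower number from compound 1 to compound 3 (0.09 log units; within the scatter) is small and toward a lower number. For compound 3 the estimated value is 1500 nM with an expected range from 600 nM to 4500 nM on this read-out.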

Compound 3, concentration for 50% growth inhibition: 953 nM
Beside the measured number, compound 3's estimate is 1.6-fold (0.20 log units) above it; the range from low to high includes it.
By their numbers in this assay, from the lowest: compounds 2, 3 and 1 (each within the scatter of the next, the first and the last beyond it).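

On this amide-type nitrogen, isobutyl in place of the amide hydrogen gives, in this assay, a 1.9-fold lower number from compound 1 to compound 3 (0.28 log units; within the scatter); the read-out therefore stays within the scatter with this added chain, and the position accepts isobutyl without a step that can be told from repeat measurement. Within the data shown here, this is the first single-place step, and it rests on one pair. No supporting data bear on the reason for this result.

Open, from the compounds shown here alone, is whether a longer chain, a cyclopentyl ring, a primary amine or a carboxylic acid on this nitrogen would give a step beyond the scatter. Also open, going by these compounds, is whether any such step would hold with a different group elsewhere on the core of compound 1.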